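This account rests on a few compounds, and the source may have more. Where it says the series, first, only, none or still open, it means among the compounds named here.

Compound 3 `CCON=C1CCC(CN2CCN(c3nc(=O)c4cc(C(F)(F)F)cc([N+](=O)[O-])c4s3)CC2)CC1` shares its core with compound 1 `CO/N=C(\C)CCN1CCN(c2nc(=O)c3cc(C(F)(F)F)cc([N+](=O)[O-])c3s2)CC1` and compound 2 `CCO/N=C(\C)CCN1CCN(c2nc(=O)c3cc(C(F)(F)F)cc([N+](=O)[O-])c3s2)CC1`, differing from them only in the chain that hangs on the amine nitrogen of the ring. In an ADME assay on Vero cells (Chlorocebus sabaeus) for cytotoxicity (on this read-out lower numbers stand for higher toxicity in this test and higher numbers for lower toxicity in this test), compound 1 gives > 64 ug/mL, which is a limit of the assay and not a number. In this assay compound 2 gives > 64 ug/mL, again a limit. Compound 3 gives > 64 ug/mL in this assay, also a limit. Compound 3 therefore stands where every measured compound stands, at the limit of > 64 ug/mL in this assay, at which 3 of the 3 values shown sit. The steps a step that the two limits leave unreadable from compound 1 to compound 2, a step that the two limits leave unreadable from compound 1 to compound 3 and a step that the two limits leave unreadable from compound 2 to compound 3 cannot be sized for this reason.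

Compound 4 `CCON=C1CCC(CN2CCN(c3nc(=O)c4cc(C(F)(F)F)cc([N+](=O)[O-])c4s3)[C@@H](C)C2)CC1` differs from compound 3 by methyl in place of hydrogen on a saturated ring carbon. Within the data shown here, none of the measured steps touches this ring carbon; all of them alter the chain on the ring nitrogen, and all of them left the read-out at the limit. They bear on the new step only in that no change tried so far has pulled a value below the limit, so no shift beyond the scatter is expected for this change either. Compound 4 is therefore expected to give 80 ug/mL in this assay, most likely again as a limit, with a range from 40 ug/mL to 160 ug/mL. The step that the limit leaves unreadable from compound 3 to compound 4 is thus estimated to be flat.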

Compound 4, half-maximal cytotoxic concentration: > 64 ug/mL
Compound 4 ended at the assay's limit (the forecaster's own chance of this, stated with the estimate: 80%); the middle value does not contradict the limit.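

Compound 4 gives > 64 ug/mL in this assay, which is a limit and not a number, so methyl in place of hydrogen on the saturated ring carbon yields no readable step from compound 3 to compound 4: the limit of > 64 ug/mL in this assay, at which 4 of the 4 values shown sit. The compounds shown leave open whether any change to the shared core or its chain would bring this read-out to a measurable number.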